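Moving a Chlorine Around a Benzyl Sulfide

The source may hold more compounds than are shown below. What is called first, only, known or untested is meant among the compounds shown, and "the series" means these compounds.

Compound 1 `COc1ccc(C2N=C(SCc3cccc(Cl)c3)NC(C)=C2C(=O)Nc2ccc(Br)cc2)cc1` and compound 2 `COc1ccc(C2N=C(SCc3ccc(Cl)cc3)NC(C)=C2C(=O)Nc2ccc(Br)cc2)cc1` share one core and differ only in where the chlorine sits on the benzyl group attached through sulfur. In a functional assay on the whole organism (artery, strain albino) with Rattus norvegicus as the target, with a stated time of 60 min, at a dose of 10 mg/kg by the oral route (a higher number here means more inhibition at the dose given (going by the name of the read-out), a lower number less inhibition), compound 1 gives 15.4%, and compound 2 gives 12.3%. The change between them is 4-chlorophenyl in place of 3-chlorophenyl on a saturated chain carbon bound to a sulfur, and the step it made, a number 3.1 percentage points lower from compound 1 to compound 2 (within the scatter), is too small to count as a real difference. Compound 3 `CC1=C(C(=O)Nc2ccc([N+](=O)[O-])cc2)C(c2cccc([N+](=O)[O-])c2)N=C(SCc2cccc(Cl)c2)N1` is built on a different core; how that core differs from the core of compound 1 is not broken down here. In this assay compound 3 gives 8.2%, which sits within the usual scatter of both compound 1 and compound 2, so the numbers of the three are level and none can be called higher or lower than the others.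

Compound 4 `CC1=C(C(=O)Nc2ccc([N+](=O)[O-])cc2)C(c2cccc([N+](=O)[O-])c2)N=C(SCc2ccc(Cl)cc2)N1` has not yet been measured. It stands to compound 3 as compound 2 stands to compound 1: the change is 4-chlorophenyl in place of 3-chlorophenyl on a saturated chain carbon bound to a sulfur, the same change in the same place. Among the compounds with values here, since the first instance of this change produced only a number 3.1 percentage points lower from compound 1 to compound 2 (within the scatter), the expectation is that the second instance gives a step of about the same size, a number 2.2 percentage points lower from compound 3 to compound 4 (within the scatter), while the assumption that the different core leaves this unchanged is one the three measured compounds cannot confirm. On that basis compound 4 is expected to give 6% in this assay, with a likely range from -2% to 16%.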

Compound 4, a percentage reported as inhibition, in the whole organism at one dose (the size of the read-out at that dose, not a potency): 6.7%
Compound 4: middle estimate off by 0.7 percentage points, on the low side, and the stated range covers the measured number.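

Putting 4-chlorophenyl in place of 3-chlorophenyl on the core of compound 3 gives, in this assay, a number 1.5 percentage points lower from compound 3 to compound 4 (within the scatter), so on this second core the change again makes no real difference to the read-out. Set side by side, the two instances of the change agree: the same change on two cores in this assay, a number 3.1 percentage points lower (within the scatter) from compound 1 to compound 2 and a number 1.5 percentage points lower (within the scatter) from compound 3 to compound 4, 1.6 percentage points apart, within the scatter of two such steps. This shows that, for these two cores, moving the chlorine on the benzyl group attached through sulfur made no difference that can be told from scatter, but because both steps are so small, it does not show that a change with a clear effect would carry from one core to the other, nor does it show whether the chlorine's place has a small true effect or none at all, and two cores tested at a single dose are too few to speak for the whole series.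

The compounds shown leave open what happens when something other than chlorine sits on the benzyl group, such as an amine or a carboxylic acid. They also leave open whether a longer chain in place of the benzyl group would give a step large enough to compare across the two cores.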